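Compound 3 and its fluoro replacement

The source may report more compounds than this note shows. Statements on the series, on what has been measured and on what is new or still open speak of the compounds shown alone.

Values so far in a physicochemical assay for solubility, read by nephelometry (on this read-out lower numbers stand for lower solubility and higher numbers for higher solubility), are as follows.
compound 1 `CN1CCN(c2cc(CN3C(=O)N(c4ccc(SC(F)(F)F)cc4)C(=O)C3(C)C)ccn2)CC1` gives 0.159 ug/mL 
compound 2 `CC1(C)C(=O)N(c2ccc(SC(F)(F)F)cc2)C(=O)N1Cc1ccnc(C(=O)O)c1` gives 0.142 ug/mL 
compound 3 `CC1(C)C(=O)N(c2ccc(SC(F)(F)F)cc2)C(=O)N1Cc1ccnc(F)c1` gives 0.032 ug/mL 

Compound 3 holds the lowest of the three numbers, and both other compounds stand beyond the scatter from it. The next step leads to compound 4 `COc1ccc(CNc2cc(CN3C(=O)N(c4ccc(SC(F)(F)F)cc4)C(=O)C3(C)C)ccn2)cc1`, with (4-methoxybenzyl)amino in place of fluoro on an aromatic carbon. Two measured steps arrive at fluoro from other groups at this place, and both are modest: a 5.0-fold lower number from compound 1 to compound 3 (0.70 log units; beyond the scatter) and a 4.4-fold lower number from compound 2 to compound 3 (0.65 log units; beyond the scatter). The two groups they start from show a 1.1-fold lower number from compound 1 to compound 2 (0.05 log units; within the scatter), which gives no order between them. Compound 4 reverses that kind of step, with fluoro leaving. Going by the values given here, no measured compound carries the entering group, so the read-across is weak. In this assay the expected move is toward a higher number, smaller than those two steps: a 1.9-fold higher number from compound 3 to compound 4 (0.27 log units; within the scatter) is the expected step. The estimate for compound 4 is 0.06 ug/mL (expected range 0.02 ug/mL to 0.2 ug/mL).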

Compound 4, solubility: < 0.027 ug/mL
Compound 4 was reported as a limit (the forecaster's own chance of this, stated with the estimate: 5%); middle value at least 2.2-fold (0.34 log units) away from the limit.
By their numbers in this assay, from the lowest: compound 3; then compounds 2 and 1 (each within the scatter of the next). At a limit, below all of these: compound 4.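

In this assay compound 4 is reported as a limit and not as a number: the limit of < 0.027 ug/mL in this assay, at which 1 of the 4 values shown sits. Against the two earlier groups at this place, next to the ring nitrogen, the change reads clearly, with an at least 5.2-fold lower number from compound 2 to compound 4 (0.72 log units; beyond the scatter) and an at least 5.8-fold lower number from compound 1 to compound 4 (0.77 log units; beyond the scatter), so a group as large as (4-methoxybenzyl)amino does not bring the number back to the level of compound 1 or compound 2. Against fluoro it gives no order, since an at least 1.1-fold lower number from compound 3 to compound 4 (0.07 log units; that floor lies within the scatter) has a floor that lies within the scatter, and the low end of the series now holds compound 3 and compound 4 together.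

From the compounds shown here alone, how far compound 4 lies beyond its limit remains open. Also open, going by these compounds, is whether a plain amino group or a morpholine ring at this place would stand with compound 1 and compound 2 or with compound 3 and compound 4.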